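Aryl swap on the shared core: pyrazinyl to pyridyl

The compounds below may be only part of what the source reports. "The series", "measured", "known", "first", "only" and "open" are said of these compounds alone.

Compound 1 `CCc1ccc(Nc2nccc(-c3cnccn3)n2)cc1` gives 1900 nM in a functional assay for inhibition, with Homo sapiens as the target (a higher number here means a weaker inhibitor, a lower number a stronger inhibitor), the lowest of the two numbers obtained; compound 2 `CCc1cccc(Nc2nccc(-c3ccco3)n2)c1` gives 9700 nM in this assay, a gap beyond the usual scatter. Compound 3 `Cc1cc(C)cc(Nc2nc(C)cc(-c3ccco3)n2)c1` reaches only the limit of this assay, recorded as > 24000 nM. Compound 4 `CCc1ccc(Nc2nccc(-c3ccncc3)n2)cc1` is not yet measured; it differs from compound 1 in one place (pyridin-4-yl in place of pyrazin-2-yl on an aromatic carbon). Among the measured compounds shown here, no measured pair isolates this change, so its size is uncertain; a step within the scatter, tending toward a slightly higher number, is expected, since one hydrogen-bond acceptor leaves. For compound 4 the expected value in this assay is 2500 nM, between 800 nM and 8000 nM, which amounts to a 1.3-fold higher number from compound 1 to compound 4 (0.12 log units; within the scatter).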

Compound 4, half-maximal inhibitory concentration: 7700 nM
Compound 4: the middle estimate sits 3.1-fold (0.49 log units) below what was measured; low and high end bracket the measured number.
By their numbers in this assay, from the lowest: compound 1; then compounds 4 and 2 (each within the scatter of the next). At a limit, above all of these: compound 3.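

On the shared core, the ring at this place matters in this assay: pyridin-4-yl in place of pyrazin-2-yl gives a 4.1-fold higher number from compound 1 to compound 4 (0.61 log units; beyond the scatter), the first single-place change available in the series. The swap removes a ring nitrogen and a hydrogen-bond acceptor together, so the step cannot be assigned to the count of nitrogens or to their placement. Nothing measured here accounts for the size of this step. On these data alone, whether pyridin-2-yl, pyridin-3-yl or phenyl at this place would separate those two readings remains open. So does the effect of an amine on this ring.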